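Phenyl in place of fluoro on compound 3

A few compounds are considered here, and "the series" means these few. Any claim that something is new, unique, unknown or untested is made for them only; others in the source may bear on it.

Three measured compounds share one core bearing an acetic acid and two aryl groups. Compound 1 `O=C(O)Cc1sc(Nc2ccccc2)nc1-c1ccc(F)cc1` gives 1300 nM in an in vitro functional assay on HEK285-7 cells for antagonist activity at prostaglandin D2 receptor 2 (Homo sapiens), read by BRET and beta-arrestin recruitment; a higher number here means a weaker inhibitor, a lower number a stronger inhibitor. Compound 2 `O=C(O)Cc1sc(Nc2ccc(Cl)cc2)nc1-c1ccc(F)cc1` gives 1900 nM in this assay, and a 1.5-fold higher number from compound 1 to compound 2 (0.16 log units; within the scatter). Compound 3 `O=C(O)Cc1sc(-c2ccccc2)nc1-c1ccc(F)cc1` gives 860 nM in this assay; a 1.5-fold lower number from compound 1 to compound 3 (0.18 log units; within the scatter) and a 2.2-fold lower number from compound 2 to compound 3 (0.34 log units; beyond the scatter). Compound 3 therefore holds the lowest number of the three, but its gap to compound 1 is within the scatter and only its gap to compound 2 is beyond it.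

Compound 4 `O=C(O)Cc1sc(-c2ccccc2)nc1-c1ccc(-c2ccccc2)cc1` differs from compound 3 by phenyl in place of fluoro on an aromatic carbon; the change sits on an aromatic carbon of a six-membered aromatic ring of carbon only, para to a large group. For the measured compounds named here, none of the measured steps touches this ring: the step from compound 1 to compound 2 alters the anilino ring, and the two steps into compound 3 exchange anilino for phenyl on the core. Going by the values given here, no measured step bears directly on the present change, and all three measured steps were small. The expectation for compound 4 is accordingly a step of a 1.2-fold lower number from compound 3 to compound 4 (0.09 log units; within the scatter) in this assay, not clearly beyond the scatter. Compound 4 is estimated at 700 nM, with a range from 250 nM to 2500 nM.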

Compound 4, half-maximal inhibitory concentration: 38 nM
Compound 4: the middle estimate sits 18-fold (1.27 log units) above what was measured, outside the stated range (below it).
By their numbers in this assay, from the lowest: compound 4; then compounds 3, 1 and 2 (each within the scatter of the next, the first and the last beyond it).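

For the compounds shown here, the ring that carries fluoro in compound 3 emerges as the most responsive place so far: phenyl in place of fluoro, on an aromatic carbon of a six-membered aromatic ring of carbon only, para to a large group, gives a 23-fold lower number from compound 3 to compound 4 (1.35 log units; beyond the scatter) in this assay. Going by these compounds alone, the largest earlier step, at the other aryl group on the shared core, was a 2.2-fold lower number from compound 2 to compound 3 (0.34 log units; beyond the scatter), so changes there gave no indication of a step of this size at the fluoro-bearing ring. Nothing available on the compounds accounts for the gain, so the step stands as an observation without an explanation.

Going by these compounds, with only fluoro and phenyl compared at this place, it remains open whether the gain requires a second aromatic ring or follows from the added carbon atoms alone, a question that a cyclohexyl group, a benzyl group or a pyridyl ring in the same place would address. On these data alone, it also remains open whether the step carries over to the anilino and (4-chlorophenyl)amino groups of compound 1 and compound 2.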